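Gem-dimethyl homologue of a piperazine glycine transporter inhibitor

The source may report more compounds than this note shows. Statements on the series, on what has been measured and on what is new or still open speak of the compounds shown alone.

Measured so far:
compound 1 `COc1ccc(Sc2ccccc2N2CCN(CC(=O)O)C(C)C2)cc1`: 1700 nM
compound 2 `COc1ccc(Sc2ccccc2N2CCN(CC(=O)O)CC2)cc1`: > 10000 nM

Going by the values given here, in an assay for inhibition of sodium- and chloride-dependent glycine transporter 1 (Homo sapiens) (a lower number here means a stronger inhibitor, a higher number a weaker inhibitor), compound 1 holds the only finite number; the other value is a limit. Compound 2 gives > 10000 nM in this assay, a limit of the assay and not a number. The step of an at least 5.8-fold higher number from compound 1 to compound 2 (0.76 log units; beyond the scatter) shows that the methyl on the saturated ring carbon matters, with the proviso of the limit of > 10000 nM in this assay, at which 1 of the 2 values shown sits.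

Compound 3 `COc1ccc(Sc2ccccc2N2CCN(CC(=O)O)C(C)(C)C2)cc1` differs from compound 1 by methyl in place of hydrogen on a saturated ring carbon. Among the compounds with values here, the only measured step, from compound 1 to compound 2, went the other way and was at least modest; it says nothing direct about a second methyl on the same carbon. No loss beyond the scatter is expected, and a small gain is possible. Compound 3 is therefore estimated at 1200 nM (range 400 nM to 4000 nM), a step of a 1.4-fold lower number from compound 1 to compound 3 (0.15 log units; within the scatter) that is expected to sit within the scatter.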

Compound 3, half-maximal inhibitory concentration: 1500 nM
Compound 3: middle estimate off by 1.3-fold (0.10 log units), on the low side; the range from low to high includes it.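

In this assay, a methyl in place of hydrogen on the saturated ring carbon next to the ring atom that bears a carboxymethyl group, where one methyl already stands, gives no change beyond the scatter: a 1.1-fold lower number from compound 1 to compound 3 (0.05 log units; within the scatter). The earlier pair showed only that the first methyl on this carbon matters; this pair shows that the same carbon accepts a second methyl without loss. The second methyl also brings no gain, so in these compounds the benefit seen with the first methyl does not grow with the second.

From the compounds shown here alone, compound 2 gives a limit and not a number, so the full size of the step from the first methyl stays unknown: the limit of > 10000 nM in this assay, at which 1 of the 3 values shown sits. Open is whether a longer chain such as ethyl on this carbon, or an amine in place of the carboxylic acid, would hold this level.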